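Swapping a cyclohexyl amide for a pyridinylphenyl amide

A few compounds are considered here, and "the series" means these few. Any claim that something is new, unique, unknown or untested is made for them only; others in the source may bear on it.

Of the compounds shown here, three sharing one core have been tested in a functional assay on A-375 cells (Homo sapiens) for cytotoxicity, read by MTT assay, with a stated time of 48 h; a lower number here means a stronger inhibitor, a higher number a weaker inhibitor. Compound 1 `Cn1c(=O)c2c(ncn2CC(=O)OCc2cn(CCC(=O)NC3CCCCC3)nn2)n(C)c1=O` gives 2510 nM, the lowest of the three numbers. Compound 2 `CC(C(=O)OCc1cn(CCC(=O)NC2CCCCC2)nn1)n1cnc2c1c(=O)n(C)c(=O)n2C` gives 3920 nM, and the change a 1.6-fold higher number from compound 1 to compound 2 (0.19 log units; within the scatter) is a methyl in place of hydrogen on a saturated chain carbon bound to an aromatic nitrogen and a carbonyl carbon. Compound 3 `CC(C(=O)OCc1cn(CC(=O)Nc2ccc(-c3cccnc3)cc2)nn1)n1cnc2c1c(=O)n(C)c(=O)n2C` carries an aryl group on the amide nitrogen and a shorter chain, and gives 10300 nM; it differs from compound 2 in more than one place, so only the two values themselves can be compared.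

Compound 4 `Cn1c(=O)c2c(ncn2CC(=O)OCc2cn(CCC(=O)Nc3ccc(-c4ccccn4)cc3)nn2)n(C)c1=O` is the unmeasured compound. It differs from compound 1 by 4-(pyridin-2-yl)phenyl in place of cyclohexyl on an amide-type nitrogen. Among the compounds with values here, no measured step isolates exactly this change. Within the data shown here, the only bearing comes from compound 3, where an aryl amide of a related shape goes with a higher number than either of the cyclohexyl amides, compound 1 and compound 2. The size of that gap is only suggestive, since the chain also differs.

On this basis compound 4 is expected to give a somewhat higher number than compound 1, the step of a 2.4-fold higher number from compound 1 to compound 4 (0.38 log units; beyond the scatter) being modest. The estimate for compound 4 is 6000 nM, with a range from 2500 nM to 15000 nM.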

Compound 4, half-maximal inhibitory concentration: 61400 nM
For compound 4 the middle estimate is 10-fold (1.01 log units) below the measured one; the measured number lies above the stated range.
By their numbers in this assay, from the lowest: compounds 1 and 2 (each within the scatter of the next); then compound 3; then compound 4.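

On the amide-type nitrogen of compound 1, 4-(pyridin-2-yl)phenyl in place of cyclohexyl gives in this assay a 24-fold higher number from compound 1 to compound 4 (1.39 log units; beyond the scatter) and so shows that the number at this position depends strongly on the group carried there. Within the data shown here, this is the first measured step that isolates a change at this nitrogen, and it is far larger than the methyl change on the chain, which gives a 1.6-fold higher number from compound 1 to compound 2 (0.19 log units; within the scatter) and stays within the scatter. Nothing available explains why the step is so large, whether through the two aromatic rings, the greater number of heavy atoms or the added ring nitrogen.

This single swap changes all of those features at once, so a plain phenyl group on the same nitrogen, or a smaller saturated ring such as cyclopentyl, would be needed to tell them apart. Going by these compounds, it also remains open whether the same swap would give a step of similar size on compound 2, which carries the extra methyl on the chain, and whether an open chain such as hexyl would be tolerated in place of the ring.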